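Changing the aryl group on a nitroimidazooxazine series

A few compounds are considered here, and "the series" means these few. Any claim that something is new, unique, unknown or untested is made for them only; others in the source may bear on it.

This account concerns a small set of compounds built on a shared core, tested in an ADME assay on Vero cells (Chlorocebus sabaeus) for cytotoxicity, read by MTT assay, with a stated time of 72 h; on this read-out lower numbers stand for higher toxicity in this test and higher numbers for lower toxicity in this test. Compound 1 `C[C@]1(CN2CCc3nc(-c4ccccc4)ncc3C2)Cn2cc([N+](=O)[O-])nc2O1` carries a phenyl group on its bicyclic part; in this assay compound 1 gives "not determined" (no result reported), so no number is available for it. Within the data shown here, compound 2 `C[C@]1(CN2CCc3nc(-c4ccc(C(F)(F)F)cc4)ccc3C2)Cn2cc([N+](=O)[O-])nc2O1` is the one measured member: in this assay compound 2 gives > 32 ug/mL, which is a limit of the assay rather than a number. Compound 2 therefore stands at the limit described in the limit of > 32 ug/mL in this assay, at which 1 of the 2 values shown sits, and a sharper placement among the values shown is not possible.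

Compound 3 `C[C@]1(CN2CCc3nc(-c4ccc(Cl)c(F)c4)ccc3C2)Cn2cc([N+](=O)[O-])nc2O1` differs from compound 2 by 4-chloro-3-fluorophenyl in place of 4-(trifluoromethyl)phenyl on an aromatic carbon. Because compound 2 sits at the limit in the limit of > 32 ug/mL in this assay, at which 1 of the 2 values shown sits, little room remains for a measurable move upward, and no step beyond the usual scatter is expected in this assay. The step of a number no higher from compound 2 to compound 3 (the limit leaves the size open) is the expected outcome. Compound 3 is estimated to give 32 ug/mL in this assay, within a range from 16 ug/mL to 64 ug/mL, and most likely to be reported again as a limit.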

Compound 3, half-maximal cytotoxic concentration: > 32 ug/mL
Compound 3 was reported as a limit (the forecaster's own chance of this, stated with the estimate: 70%); the middle value lies on the limit itself.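

Compound 2 and compound 3 are both reported as a limit rather than a number, so no step between them can be read: the limit of > 32 ug/mL in this assay, at which 2 of the 3 values shown sit.

The compounds shown leave open how far either lies beyond that limit in this assay, and whether 4-chloro-3-fluorophenyl in place of 4-(trifluoromethyl)phenyl changes the read-out at all.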